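Naphthyl Arm on a Nucleoside Core: Expected Transporter Inhibition

This account rests on a few compounds, and the source may have more. Where it says the series, first, only, none or still open, it means among the compounds named here.

Compound 1, `Nc1ncnc2c1nc(NCc1ccccc1-c1ccccc1)n2[C@@H]1O[C@H](CO)[C@@H](O)[C@H]1O`: in an assay on COS-7 cells for inhibition of sodium/nucleoside cotransporter 2 (Homo sapiens), read by scintillation counting, in the presence of a further agent that is not named here (a lower number here means a stronger inhibitor, a higher number a weaker inhibitor), compound 1 gives > 100000 nM, a limit of the assay.
Compound 2, `COc1ccccc1CNc1nc2c(N)ncnc2n1[C@@H]1O[C@H](CO)[C@@H](O)[C@H]1O`: in this assay compound 2 gives > 100000 nM, also a limit.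
Compound 3, `CCCCCC(=O)OC[C@H]1O[C@@H](n2cnc3c(N)ncnc32)[C@H](O)[C@@H]1O`: in this assay compound 3 gives > 100000 nM, again a limit.

Compound 2 therefore stands at the limit, and so do the other two values shown (the limit of > 100000 nM in this assay, at which 3 of the 3 values shown sit). Going by the values given here, the one step that touches its side chain, a step that the two limits leave unreadable from compound 1 to compound 2, cannot be read because the limit of > 100000 nM in this assay, at which 3 of the 3 values shown sit, hides both ends. Compound 4, `Nc1ncnc2c1nc(NCc1cccc3ccccc13)n2[C@@H]1O[C@H](CO)[C@@H](O)[C@H]1O`, differs from compound 2 by naphthalen-1-yl in place of 2-methoxyphenyl on a saturated chain carbon bound to a nitrogen on an aromatic ring. No readable step bears on this change, so no direction beyond the scatter can be foreseen in this assay. Compound 4 is expected to stay at the limit, an expected step that the limit leaves unreadable from compound 2 to compound 4. The estimate for compound 4 is 150000 nM, between 40000 nM and 600000 nM.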

Compound 4, half-maximal inhibitory concentration: 5700 nM
Compound 4: the middle estimate sits 26-fold (1.42 log units) above what was measured; measured number outside the range, below it.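

Going by these compounds alone, replacing 2-methoxyphenyl with naphthalen-1-yl on this saturated chain carbon gives an at least 17-fold lower number from compound 2 to compound 4 (1.24 log units; beyond the scatter), the only step that can be read in this assay. Within the data shown here, compound 4 shows that a compound with a group at this position can give a measured number, which the earlier compounds could not show. The step's true size remains unknown, and it could be larger: the limit of > 100000 nM in this assay, at which 3 of the 4 values shown sit.

The compounds shown do not separate the effect of the second ring from that of losing the methoxy group. Going by these compounds, whether naphthalen-2-yl, or a phenyl ring carrying an amine, would perform similarly also remains open.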